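Branching the chain on the amide nitrogen: compound 3 to compound 4

The compounds below may be only part of what the source reports. "The series", "measured", "known", "first", "only" and "open" are said of these compounds alone.

Compound 1 `CCN(Cc1cccc(F)c1)C(=O)C1CCN(S(=O)(=O)c2ccc3cn[nH]c3c2)CC1` gives 89% in a functional assay on CHO cells for positive allosteric modulation of muscarinic acetylcholine receptor M5 (Homo sapiens), read by calcium flux (on this read-out higher numbers stand for larger maximal responses and lower numbers for smaller maximal responses), and compound 2 `CCN(Cc1ccccc1C(F)(F)F)C(=O)C1CCN(S(=O)(=O)c2ccc3cn[nH]c3c2)CC1` gives 92%. Among the measured compounds shown here, the one counted step between them, a number 3 percentage points higher from compound 1 to compound 2 (within the scatter), concerns the aryl group alone. Compound 3 `CC(C)N(Cc1ccccc1C(F)(F)F)C(=O)C1CCN(S(=O)(=O)c2ccc3[nH]ncc3c2)CC1` carries isopropyl where compound 1 carries ethyl, and its core differs from the core of compound 1. In this assay compound 3 gives 54%; this is the lowest of the three numbers, with compound 1 nearest and compound 2 furthest, both beyond the scatter. For the measured compounds named here, no single-place step joins compound 3 to either of them, so the gap is read from the two values only, and it cannot be split between the alkyl group and the core.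

Compound 4 `CCC(C)N(Cc1ccccc1C(F)(F)F)C(=O)C1CCN(S(=O)(=O)c2ccc3[nH]ncc3c2)CC1` differs from compound 3 by methyl in place of hydrogen on a saturated chain carbon, two bonds along the chain from an amide-type nitrogen. Going by the values given here, no measured step bears on this position. Among the compounds with values here, the only counted step, a number 3 percentage points higher from compound 1 to compound 2 (within the scatter), lies within the scatter and concerns a different part of the molecule; the values of compound 2 and compound 3 cannot be assigned to the alkyl change. The step of a number 2 percentage points lower from compound 3 to compound 4 (within the scatter) is therefore expected to stay within the scatter, with no direction inferred. Compound 4 is estimated at 52%, within a range from 36% to 70%.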

Compound 4, largest response reached (reported as percent of maximum), in percent of the reference or control that the assay uses: 100%
Beside the measured number, compound 4's estimate is 48 percentage points below it; the whole stated range lies below it.
By their numbers in this assay, from the lowest: compound 3; then compounds 1, 2 and 4 (each within the scatter of the next, the first and the last beyond it).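

In this assay the alkyl group on the amide nitrogen proves to be a sensitive place: with all else unchanged, methyl in place of hydrogen on a saturated chain carbon, two bonds along the chain from an amide-type nitrogen, gives a number 46 percentage points higher from compound 3 to compound 4 (beyond the scatter) in a single step. This change, which turns isopropyl into sec-butyl and adds 1 heavy atom with no hydrogen-bond donors or acceptors, is the only step in the series shown that lies beyond the scatter and can be tied to one place. The response therefore depends on the exact shape of this alkyl group, and a small change here is enough to move it by a large amount, though nothing available accounts for the size of the step.

Still open, from the compounds shown here alone, is whether a longer chain such as n-pentyl, or a ring such as cyclobutyl, on the amide nitrogen would hold or lose the response of compound 4. Also open, going by these compounds, is whether the same change from isopropyl to sec-butyl would have a comparable effect on the core of compound 1.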